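This account rests on a few compounds, and the source may have more. Where it says the series, first, only, none or still open, it means among the compounds named here.

The measured compounds:

Compound 1, `CC(=O)NCC[C@@H]1C[C@@H](c2ccc(F)c(F)c2)[C@H](NC(=O)c2cc(-c3c(Cl)cnn3C)c(Cl)o2)CN1`: in a functional assay on HCT-116 cells (Homo sapiens) for antiproliferative activity, read by sulforhodamine B assay, with a stated time of 72 h (on this read-out higher numbers stand for weaker inhibition and lower numbers for stronger inhibition), compound 1 gives 920 nM.
Compound 2, `CC(=O)OCC[C@@H]1C[C@@H](c2ccc(F)c(F)c2)[C@H](NC(=O)c2cc(-c3c(Cl)cnn3C)c(Cl)o2)CN1`: compound 2 gives 690 nM.
Compound 3, `COCC[C@@H]1C[C@@H](c2ccc(Cl)c(Cl)c2)[C@H](NC(=O)c2cc(-c3c(Cl)cnn3C)c(Cl)o2)CN1`: compound 3 gives 470 nM.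

Compound 3 has the lowest of the three numbers, but its gap to compound 2 and its gap to compound 1 both lie within the scatter, so the three stand together rather than in a clear order. Compound 4, `Cn1ncc(Cl)c1-c1cc(C(=O)N[C@@H]2CN[C@H](CC(O)CO)C[C@H]2c2ccc(Cl)c(Cl)c2)oc1Cl`, differs from compound 3 in one place: 1,2-dihydroxyethyl in place of methoxymethyl on a saturated chain carbon bound to a saturated ring carbon. The chain carbon carrying this group is bound to a saturated ring carbon of the shared core, and the change swaps methoxymethyl for 1,2-dihydroxyethyl.

Going by the values given here, the only measured step on a comparable chain is a 1.3-fold lower number from compound 1 to compound 2 (0.12 log units; within the scatter), where one chain group gave way to another without moving the number beyond the scatter. That step concerns different groups, so it bears on the present change only loosely. With no measured change at this part of the molecule having moved the number beyond the scatter, the expected step is a 1.3-fold higher number from compound 3 to compound 4 (0.11 log units; within the scatter), no larger than the scatter in either direction. Compound 4 is therefore estimated at 600 nM, with a range from 250 nM to 1500 nM.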

Compound 4, half-maximal inhibitory concentration: 1110 nM
For compound 4 the middle estimate is 1.9-fold (0.27 log units) below the measured one; measured number inside the range.
By their numbers in this assay, from the lowest: compounds 3, 2, 1 and 4 (each within the scatter of the next, the first and the last beyond it).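

In this assay, putting 1,2-dihydroxyethyl in place of methoxymethyl on this saturated chain carbon gives a 2.4-fold higher number from compound 3 to compound 4 (0.37 log units; beyond the scatter), a modest step but one beyond the usual scatter. Going by these compounds alone, the earlier chain step, a 1.3-fold lower number from compound 1 to compound 2 (0.12 log units; within the scatter), stayed within the scatter, so this is the first sign that the number responds to what this chain carries, here a change from 0 to 2 hydrogen-bond donors. No measurement available here explains the rise.

From the compounds shown here alone, this single swap adds both hydroxyl groups and removes the methyl ether at once, so their separate contributions remain unknown. A 2-hydroxyethyl group, an amine or a carboxylic acid at this place would help show whether the hydroxyl groups, the ether's loss or the chain's overall makeup governs the number.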